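A pyrrolidinyl-to-(methylamino)methyl swap on the piperidine carbon

A few compounds are considered here, and "the series" means these few. Any claim that something is new, unique, unknown or untested is made for them only; others in the source may bear on it.

Compound 1 `CCCCCOC(=O)N1CCN(C(=O)[C@H](CCC(=O)O)NC(=O)c2cc(N3CCC(C(=O)N(CC)CC)CC3)nc(-c3ccccc3)n2)CC1` reaches the limit > 80% in an ADME assay on microsomes from liver (Rattus norvegicus) for metabolic stability; on this read-out higher numbers stand for a more stable compound and lower numbers for a less stable compound.
Compound 2 `CCCCCOC(=O)N1CCN(C(=O)[C@H](CCC(=O)O)NC(=O)c2cc(N3CCC(OCCO)CC3)nc(-c3ccccc3)n2)CC1` reaches the limit > 80% in this assay.
Compound 3 `CCCCCOC(=O)N1CCN(C(=O)[C@H](CCC(=O)O)NC(=O)c2cc(N3CCC(N4CCCC4)CC3)nc(-c3ccccc3)n2)CC1` reaches the limit > 80% in this assay.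

Compound 3 thus stands at a limit of this assay, and it shares this position with its two neighbours (the limit of > 80% in this assay, at which 3 of the 3 values shown sit). The three measured steps among them, a step that the two limits leave unreadable from compound 1 to compound 2, a step that the two limits leave unreadable from compound 1 to compound 3 and a step that the two limits leave unreadable from compound 2 to compound 3, give no readable size and no direction. Compound 4 `CCCCCOC(=O)N1CCN(C(=O)[C@H](CCC(=O)O)NC(=O)c2cc(N3CCC(CNC)CC3)nc(-c3ccccc3)n2)CC1` differs from compound 3 by (methylamino)methyl in place of pyrrolidin-1-yl on a saturated ring carbon. Within the data shown here, no measured step informs this change. With every shown value sitting at the limit, compound 4 is expected to remain at or near it, and the expected step is a step that the limit leaves unreadable from compound 3 to compound 4. For compound 4 the estimate in this assay is 82%, between 65% and 95%.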

Compound 4, percent of the compound remaining: > 80%
Compound 4: no number, only a limit (the forecaster's own chance of this, stated with the estimate: 65%); the middle value is on the limit's open side.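

In this assay, among these compounds, compound 1, compound 2, compound 3 and compound 4 all sit at the same limit, and no step among them can be read. The compounds shown leave open how far each lies beyond that limit, and whether any of these groups differs from another in stability.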